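The source may hold more compounds than are shown below. What is called first, only, known or untested is meant among the compounds shown, and "the series" means these compounds.

Measured compounds in a functional assay on HepG2 cells (Homo sapiens) for antiproliferative activity; a higher number here means a weaker inhibitor, a lower number a stronger inhibitor:
compound 1 `CC[C@H](C)[C@H]1C(=O)N[C@H](Cc2cc(Cl)c(O)c(Cl)c2)C(=O)N[C@@H](C(C)C)C(=O)O[C@H](c2ccccc2)[C@H](C)/C=C/C=C(\C)[C@H](OC)C[C@@H]2O[C@@]2(C)C(=O)N1C`: 5.65 nM
compound 2 `CC[C@H](C)[C@H]1C(=O)N[C@H](Cc2cc(Cl)c(O)c(Cl)c2)C(=O)N[C@@H](C(C)(C)O)C(=O)O[C@H](c2ccccc2)[C@H](C)/C=C/C=C(\C)[C@H](OC)C[C@@H]2O[C@@]2(C)C(=O)N1C`: 3.36 nM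
compound 3 `CC[C@H](C)[C@H]1C(=O)N[C@H](Cc2cc(Cl)c(O)c(Cl)c2)C(=O)N[C@@H](C(C)C)C(=O)O[C@H](c2ccccc2)[C@H](C)/C=C/C=C(\C)[C@H](OC)C/C=C(\C)C(=O)N1C`: 104 nM

Compound 2 carries the change hydroxy in place of hydrogen on a saturated chain carbon bound to two saturated chain carbons and a saturated ring carbon relative to compound 1, and the step of a 1.7-fold lower number from compound 1 to compound 2 (0.23 log units; within the scatter) is small. Compound 3 gives the highest number of the three; the difference between its core and the core of compound 1 is not broken down here, so only the two values themselves are compared.

Compound 4 `CC[C@H](C)[C@H]1C(=O)N[C@H](Cc2cc(Cl)c(O)c(Cl)c2)C(=O)N[C@@H](C(C)(C)O)C(=O)O[C@H](c2ccccc2)[C@H](C)/C=C/C=C(\C)[C@H](OC)C/C=C(\C)C(=O)N1C` carries the same change on the core of compound 3: hydroxy in place of hydrogen on a saturated chain carbon bound to two saturated chain carbons and a saturated ring carbon. The place line reads the same in both pairs, so the change is the same. The step is expected to resemble the earlier one, a 1.5-fold lower number from compound 3 to compound 4 (0.17 log units; within the scatter), because the matching step a 1.7-fold lower number from compound 1 to compound 2 (0.23 log units; within the scatter) stayed within the scatter. Compound 4 is therefore estimated at 70 nM, in the range 30 nM to 200 nM.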

Compound 4, half-maximal inhibitory concentration: 2.75 nM
Beside the measured number, compound 4's estimate is 25-fold (1.41 log units) above it; the whole stated range lies above it.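

In this assay the change from isopropyl to 1-hydroxy-1-methylethyl does not carry over at a constant size between the two cores: the same change on two cores in this assay, a 1.7-fold lower number (0.23 log units; within the scatter) from compound 1 to compound 2 and a 38-fold lower number (1.58 log units; beyond the scatter) from compound 3 to compound 4, 22-fold (1.35 log units) apart, beyond the scatter of two such steps

On the core of compound 3 the change gives a 38-fold lower number from compound 3 to compound 4 (1.58 log units; beyond the scatter) and is large, so in these two pairs the size of the step depends on the core. Two pairs give no rule for other cores, and they do not show which feature of the cores accounts for the gap.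

Still open, going by these compounds, is whether an amine, a methoxy group or a carboxylic acid at this place would also give a step that differs between the two cores. A longer chain carrying the hydroxy group leaves the same question open.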